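The compounds below may be only part of what the source reports. "The series", "measured", "known", "first", "only" and "open" are said of these compounds alone.

Working notes on the series.

Two compounds have been run in a functional assay on PC-3 cells (Homo sapiens) for inhibition, read by MTT assay, with a stated time of 48 h (on this read-out higher numbers stand for weaker inhibition and lower numbers for stronger inhibition), so far. Compound 1 `C=C1CC[C@@H]2[C@](C)(CO)[C@H](O)CC[C@@]2(C)[C@@H]1C/C=C1/C(=O)OCC1OC(=O)CSc1ccc(F)cc1` gives 13000 nM in this assay. Compound 2 `C=C1CC[C@@H]2[C@](C)(CO)[C@H](O)CC[C@@]2(C)[C@@H]1C/C=C1/C(=O)OC[C@H]1OC(=O)CSc1ccc([N+](=O)[O-])cc1` gives 17000 nM in this assay. For the measured compounds named here, compound 2 thus sits beside compound 1 at the weaker end of the series: the two numbers differ by less than the usual scatter of repeated measurements, so they are read as the same level of inhibition, and no step between them is recorded.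

Compound 3 `C=C1CC[C@@H]2[C@](C)(CO)[C@H](O)CC[C@@]2(C)[C@@H]1C/C=C1/C(=O)OC[C@H]1OC(=O)CSc1cccs1` is the next member to be measured in this assay. It differs from compound 2 in one place only: thiophen-2-yl in place of 4-nitrophenyl on a sulfur. Both aryl groups tried so far on that sulfur leave the number in the same weak range, which gives no basis for expecting the thiophen-2-yl group to move it far in either direction. The step from compound 2 to compound 3 in this assay is therefore expected to stay within the scatter, a 1.1-fold lower number from compound 2 to compound 3 (0.05 log units; within the scatter). For compound 3 the estimate in this assay is 15000 nM, with a range from 6000 nM to 40000 nM.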

Compound 3, half-maximal inhibitory concentration: 18000 nM
For compound 3 the middle estimate is 1.2-fold (0.08 log units) below the measured one; low and high end bracket the measured number.
By their numbers in this assay, from the lowest: compounds 1, 2 and 3 (each within the scatter of the next).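

For the compounds shown here, compound 3 gives the first one-place comparison at this position: in this assay, thiophen-2-yl in place of 4-nitrophenyl on a sulfur gives a 1.1-fold higher number from compound 2 to compound 3 (0.02 log units; within the scatter) and so leaves the level of inhibition unchanged. The change is a large one in structural terms, going from a six-membered aromatic ring of carbon only with 9 heavy atoms to a five-membered aromatic ring with 1 hetero atom and 5 heavy atoms, and it also removes the nitro group, yet for this pair the read-out does not register it. No measured data on the compounds bear on why this exchange leaves the number in place.

Going by these compounds, the pair covers only aromatic rings on this sulfur, so it remains open whether a group of another kind there, such as an aminoethyl chain, a carboxymethyl chain or a cyclohexyl ring, would move the number beyond the scatter. On these data alone, it also remains open whether the number responds to changes elsewhere, for example an amide in place of the ester that joins the sulfur-bearing chain to the shared core.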